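The source may report more compounds than this note shows. Statements on the series, on what has been measured and on what is new or still open speak of the compounds shown alone.

Compound 1 `COc1ccc(-c2cn3cc(-c4ccccc4)nc3c(N)n2)cc1`: 20%
Compound 2 `Nc1nc(-c2ccc(Cl)cc2)cn2cc(-c3ccccc3)nc12`: 3%

In an assay on cells for displacement of a labelled ligand from adenosine receptor A1 (Homo sapiens), read by scintillation counting, with a stated time of 120 min, tested at 1 uM (a higher number here means more inhibition at the concentration tested (going by the name of the read-out), a lower number less inhibition), compound 1 gives 20%, while compound 2 gives 3%. Among the compounds with values here, compound 2 thus stands lowest of the two numbers, and the nearest neighbour is compound 1, which lies higher by the only measured step, a number 17 percentage points lower from compound 1 to compound 2 (beyond the scatter), a chloro in place of methoxy on the aromatic carbon.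

Compound 3 `Nc1nc(-c2ccc(OCc3ccccc3)cc2)cn2cc(-c3ccccc3)nc12` differs from compound 2 by benzyloxy in place of chloro on an aromatic carbon. Within the data shown here, that step bears on the same aromatic carbon as the one measured step, and it brings back an oxygen-linked group where compound 1 carries methoxy. Among the measured compounds shown here, since compound 1 gives 20%, a modest rise is expected in this assay for compound 3, though the benzyloxy is far larger than methoxy and the single step offers little to calibrate it. Compound 3 is therefore expected to give 15%, within 0% to 35%, a step estimated as a number 12 percentage points higher from compound 2 to compound 3 (beyond the scatter).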

Compound 3, a percentage reported as inhibition, at one concentration (the size of the read-out at that concentration, not a potency): 10%
The estimate for compound 3 lay 5 percentage points above the measured number; low and high end bracket the measured number.
By their numbers in this assay, from the lowest: compounds 2, 3 and 1 (each within the scatter of the next, the first and the last beyond it).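

Placed para to a large group in this assay, benzyloxy brings in a far larger group with one more six-membered aromatic ring, yet the change from chloro gives a number 7 percentage points higher from compound 2 to compound 3 (within the scatter) and so cannot be told from no change. Phenyl in place of hydrogen on the chain carbon bound to the oxygen gives a number 10 percentage points lower from compound 1 to compound 3 (within the scatter) and likewise cannot be told from no change. Compound 3 thus lies within the scatter of both neighbours, so the number in this read-out is level with the larger group at this position, without settling whether the oxygen link matters, and nothing measured here offers an explanation.

The compounds shown leave open how an amine or a carboxylic acid at this position would read. They also leave open whether a longer chain between the oxygen and the phenyl would change the number.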